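The compounds below may be only part of what the source reports. "The series", "measured", "known", "first", "only" and "open" are said of these compounds alone.

Compound 1 `COC(=O)c1sc2cc(OC)ccc2c1C#Cc1ccccc1`: 79600 nM
Compound 2 `COC(=O)c1sc2cc(OC)ccc2c1C#Cc1ccc(F)cc1`: 12600 nM

In a functional assay on MCF7 cells (Homo sapiens) for cytotoxicity, read by sulforhodamine B assay, with a stated time of 48 h (a higher number here means a weaker inhibitor of growth, a lower number a stronger inhibitor of growth), compound 2 gives 12600 nM, the lowest of the two numbers in hand, and compound 1 gives 79600 nM. Among the compounds with values here, the only step between measured compounds, a 6.3-fold lower number from compound 1 to compound 2 (0.80 log units; beyond the scatter), lies beyond the scatter.

Compound 3 `COC(=O)c1sc2cc(OC)ccc2c1C#Cc1ccccc1F` has not yet been measured in this assay. It differs from compound 2 in one place: 2-fluorophenyl in place of 4-fluorophenyl on a triple-bonded carbon. The same atoms are present in both; only the position of the fluorine on the ring changes.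

Within the data shown here, no measured step bears directly on moving a fluorine from one ring position to another. Among the measured compounds shown here, the single step in hand, a 6.3-fold lower number from compound 1 to compound 2 (0.80 log units; beyond the scatter), shows that adding fluorine at the position found in compound 2 brought a modest improvement over compound 1, but it says nothing about the position used in compound 3. With no closer guide, compound 3 is expected to fall between the two measured numbers, nearer compound 2 than compound 1, with the step of a 2.0-fold higher number from compound 2 to compound 3 (0.30 log units; within the scatter) estimated as small and not necessarily beyond the scatter. Compound 3 is therefore estimated at 25000 nM in this assay, within a range of 8000 nM to 80000 nM.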

Compound 3, concentration for 50% growth inhibition: 11400 nM
Estimate against measurement, compound 3: 2.2-fold (0.34 log units) above; the range from low to high includes it.
By their numbers in this assay, from the lowest: compounds 3 and 2 (each within the scatter of the next); then compound 1.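

Read in this assay the step from the 4-fluorophenyl to the 2-fluorophenyl on the triple-bonded carbon (a 1.1-fold lower number from compound 2 to compound 3 (0.04 log units; within the scatter)) lies within the scatter, so compound 2 and compound 3 cannot be told apart, and between these two ring positions the place of the fluorine makes no readable difference. The second fluorinated compound also stands clear of the unfluorinated one (a 7.0-fold lower number from compound 1 to compound 3 (0.84 log units; beyond the scatter)), which means that the gain seen earlier with compound 2 is not confined to a single ring position: both fluorinated phenyl groups shown go the same way against compound 1, and neither compound goes against this within these three. No measurement given here explains why fluorine on this ring goes with a lower number or why its two positions read alike.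

What the compounds shown leave open is whether the effect belongs to fluorine itself or would also appear with another group on this phenyl ring, such as chloro, a nitrile or an amine. They also leave open how the numbers would respond if the methyl ester on the shared core gave way to a carboxylic acid or an amide.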